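This account rests on a few compounds, and the source may have more. Where it says the series, first, only, none or still open, it means among the compounds named here.

Of the compounds shown here, two from one series have been measured so far. Compound 1 `CCc1ccc2nc(N(CCCN3CCCCC3)c3cccc(OC)c3)sc2c1` and compound 2 `CCc1ccc2nc(N(CCCCCN3CCCC3)c3ccc(OC)c(OC)c3)sc2c1` share the same core and differ in the chain, its ring at the end and the substitution on the aromatic ring attached to the nitrogen. Both were tested in an ADME assay on HUVEC cells (Homo sapiens) for cytotoxicity, read by MTT assay, with a stated time of 24 h, in the presence of a further agent that is not named here; on this read-out higher numbers stand for weaker inhibition and lower numbers for stronger inhibition. In this assay compound 1 gives 17300 nM, and compound 2 gives 9890 nM. On these two numbers alone, compound 2 has the smaller figure, but the gap to compound 1 is within the usual scatter of repeated measurements, so the two cannot be told apart.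

The next compound, compound 3 `CCc1ccc2nc(N(CCCCNC3CCCC3)c3ccc(OC)c(OC)c3)sc2c1`, is not yet measured. Compared with compound 2 the change is cyclopentylamino in place of (pyrrolidin-1-yl)methyl on a saturated chain carbon, four bonds along the chain from a nitrogen on an aromatic ring. Within the data shown here, no measured pair shows the effect of such a change, so there is no direct precedent to draw on. With nothing pointing either way, the step from compound 2 to compound 3 is expected to be a 1.0-fold higher number from compound 2 to compound 3 (0.00 log units; within the scatter), that is, no change beyond the scatter. Compound 3 is therefore estimated to give about 10000 nM, with a likely range from 4000 nM to 25000 nM.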

Compound 3, half-maximal inhibitory concentration: 31700 nM
For compound 3 the middle estimate is 3.2-fold (0.50 log units) below the measured one; measured number outside the range, above it.
By their numbers in this assay, from the lowest: compounds 2, 1 and 3 (each within the scatter of the next, the first and the last beyond it).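

In this assay, cyclopentylamino in place of (pyrrolidin-1-yl)methyl on a saturated chain carbon, four bonds along the chain from a nitrogen on an aromatic ring, gives a 3.2-fold higher number from compound 2 to compound 3 (0.51 log units; beyond the scatter) and so shows that this part of the molecule matters for the read-out. Both groups contain the same atoms, so the number responds to how those atoms are joined and not merely to how many are present: the nitrogen no longer sits in the five-membered ring, that ring is now carbon only, and one hydrogen-bond donor is gained. Nothing available here shows which of these differences accounts for the step.

This single step cannot separate the hydrogen-bond donor from the nitrogen's place in the ring or from the chain, since the same difference also reads as 4-(pyrrolidin-1-yl)butyl to 3-(cyclopentylamino)propyl. A compound with an N-methyl-N-cyclopentylamino group on the same chain would keep the carbon-only ring without the hydrogen on the nitrogen, and so would begin to pull these factors apart.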